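Adding a trifluoromethoxy group to the sulfonyl ring

A few compounds are considered here, and "the series" means these few. Any claim that something is new, unique, unknown or untested is made for them only; others in the source may bear on it.

Measured compounds:
compound 1 `CN(C(=O)c1ccc(Br)cc1)c1ccc2[nH]c(-c3n[nH]c4ccccc34)cc2n1`: 3460 nM
compound 2 `CN(C(=O)c1ccco1)c1ccc2[nH]c(-c3n[nH]c4ccccc34)cc2n1`: 28200 nM
compound 3 `CN(c1ccc2[nH]c(-c3n[nH]c4ccccc34)cc2n1)S(=O)(=O)c1ccccc1`: 12000 nM

In a functional assay on SMMC-7721 cells (Homo sapiens) for antiproliferative activity, read by MTT assay, with a stated time of 72 h (a lower number here means a stronger inhibitor, a higher number a weaker inhibitor), compound 3 stands second highest of the three numbers, with a 3.5-fold higher number from compound 1 to compound 3 (0.54 log units; beyond the scatter) and a 2.4-fold lower number from compound 2 to compound 3 (0.37 log units; beyond the scatter). Compound 4 `CN(c1ccc2[nH]c(-c3n[nH]c4ccccc34)cc2n1)S(=O)(=O)c1ccc(OC(F)(F)F)cc1` differs from compound 3 by trifluoromethoxy in place of hydrogen on an aromatic carbon. For the measured compounds named here, none of the measured steps places a group on the ring of a phenylsulfonyl, so no step bears directly on this change; the steps seen, an 8.2-fold higher number from compound 1 to compound 2 (0.91 log units; beyond the scatter) and a 3.5-fold higher number from compound 1 to compound 3 (0.54 log units; beyond the scatter), swap whole groups rather than decorate one ring. The step to compound 4 is therefore expected to be small, probably within the scatter, with a 1.3-fold lower number from compound 3 to compound 4 (0.12 log units; within the scatter). Compound 4 is estimated at 9000 nM, within 3500 nM to 25000 nM.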

Compound 4, half-maximal inhibitory concentration: 7160 nM
For compound 4 the middle estimate is 1.3-fold (0.10 log units) above the measured one; low and high end bracket the measured number.
By their numbers in this assay, from the lowest: compound 1; then compounds 4 and 3 (each within the scatter of the next); then compound 2.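

In this assay, phenyl to 4-(trifluoromethoxy)phenyl gives a 1.7-fold lower number from compound 3 to compound 4 (0.22 log units; within the scatter). This is the only step shown that decorates the sulfonyl ring rather than swapping a whole group, and at this place it does not separate compound 4 from compound 3. No measurement at hand bears on this result. From the compounds shown here alone, whether an amine or a carboxylic acid at this same place would give a step beyond the scatter remains open. So does what trifluoromethoxy would do in place of the bromine of compound 1.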